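The source may hold more compounds than are shown below. What is called first, only, known or untested is meant among the compounds shown, and "the series" means these compounds.

Measured so far in an ADME assay on HT-29 cells (Homo sapiens) for inhibition, read by MTT assay, with a stated time of 72 h; a lower number here means a stronger inhibitor, a higher number a weaker inhibitor:

Compound 1 `C=CC(=O)Nc1cccc(Nc2nc(N/N=C/c3ccccc3F)ncc2Cl)c1`: 3500 nM
Compound 2 `C=CC(=O)Nc1cccc(Nc2nc(N/N=C(\C)c3ccc(F)cc3)ncc2Cl)c1`: 5050 nM

In this assay compound 2 carries the higher of the two numbers, but the step of a 1.4-fold higher number from compound 1 to compound 2 (0.16 log units; within the scatter) lies within the scatter, so the two compounds count as alike. Compound 3 `C=CC(=O)Nc1cccc(Nc2nc(N/N=C(\C)c3ccc(F)cc3F)ncc2Cl)c1` differs from compound 2 by fluoro in place of hydrogen on an aromatic carbon. Among the measured compounds shown here, no measured step adds a fluoro to this ring; the only known step, a 1.4-fold higher number from compound 1 to compound 2 (0.16 log units; within the scatter), changed a different part and was small. The expected step is therefore a 1.0-fold lower number from compound 2 to compound 3 (0.00 log units; within the scatter), nothing beyond the scatter. For compound 3 the estimate is 5000 nM, ranging from 2500 nM to 10000 nM.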

Compound 3, half-maximal inhibitory concentration: 4360 nM
Estimate against measurement, compound 3: 1.1-fold (0.06 log units) above; measured number inside the range.
By their numbers in this assay, from the lowest: compounds 1, 3 and 2 (each within the scatter of the next).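

In this assay, fluoro on the aromatic carbon ortho to a large group, turning 4-fluorophenyl into 2,4-difluorophenyl, gives a 1.2-fold lower number from compound 2 to compound 3 (0.06 log units; within the scatter), so compound 2 and compound 3 count as alike. This is the first step shown on this ring, and it indicates that this position accepts a fluoro with no change beyond the scatter. Nothing available explains the outcome.

Going by these compounds, whether a larger group here, such as a methoxy or an amine, would shift the number beyond the scatter remains open. So does the effect of a chlorine at this position.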